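The compounds below may be only part of what the source reports. "The series", "measured", "known", "first", "only" and "open" are said of these compounds alone.

Measured so far in a functional assay on UV4 cells (Cricetulus griseus) for cytotoxicity, with a stated time of 4 h; a lower number here means a stronger inhibitor, a higher number a weaker inhibitor:
- compound 1 `CS(=O)(=O)N1CC(CCl)c2ccc(O)cc21`: 1900 nM
- compound 2 `CS(=O)(=O)N1CC(CCl)c2ccc(S)cc21`: 124000 nM

Compound 2 stands at the highest of the two numbers in this assay; its nearest neighbour is compound 1, and the step of a 65-fold higher number from compound 1 to compound 2 (1.81 log units; beyond the scatter) is the only one recorded in the series, a large rise for sulfanyl in place of hydroxy on an aromatic carbon.

Compound 3 `CSc1ccc2c(c1)N(S(C)(=O)=O)CC2CCl` is not yet measured. It differs from compound 2 by methyl in place of hydrogen on a sulfur; cut one bond further out, the change reads sulfanyl to methylsulfanyl. Among the measured compounds shown here, no measured step touches a substituent on the sulfur, so the recorded step from compound 1 to compound 2 gives no direct guide: it concerns the exchange of the whole group on the aromatic carbon, not what sits on the sulfur. The working expectation is therefore no step beyond the scatter in this assay, with wide uncertainty in both directions because the series holds only two points. On that basis compound 3 is estimated at 60000 nM in this assay, within a range of 10000 nM to 300000 nM. On these data alone, the step this estimate implies, a 2.1-fold lower number from compound 2 to compound 3 (0.32 log units; beyond the scatter), is an expectation only and remains open to a larger move once the number is in hand.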

Compound 3, half-maximal inhibitory concentration: > 200000 nM
Compound 3: only a limit was reported; the forecaster's own chance of this, stated with the estimate: 20%; middle value at least 3.3-fold (0.52 log units) away from the limit.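

In this assay the result for compound 3 is a limit and not a number: the limit of > 200000 nM in this assay, at which 1 of the 3 values shown sits.

Methyl on the sulfur brings no return to the level of the hydroxy compound, with an at least 100-fold higher number from compound 1 to compound 3 (2.02 log units; beyond the scatter). The large rise on leaving hydroxy is therefore now seen with two sulfur groups on that aromatic carbon, sulfanyl and methylsulfanyl, and not with sulfanyl alone. Against sulfanyl itself the record shows an at least 1.6-fold higher number from compound 2 to compound 3 (0.20 log units; that floor lies within the scatter), so neither a further loss nor parity can be read from the methyl, only the absence of any recovery.

On these data alone, how far methylsulfanyl really lies from sulfanyl stays open while the result for compound 3 remains a limit. Also open, as far as these compounds go, is whether the rise belongs to sulfur as such, which a methoxy group or an amine on the same aromatic carbon would test from the oxygen and nitrogen side, and a methylsulfonyl group from the side of oxidised sulfur.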